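A few compounds are considered here, and "the series" means these few. Any claim that something is new, unique, unknown or untested is made for them only; others in the source may bear on it.

Working notes on the series, read in a functional assay on L1210 cells (Mus musculus) for inhibition; on this read-out higher numbers stand for weaker inhibition and lower numbers for stronger inhibition. Compound 1 `C#CCN(Cc1ccc2nc(C)nc(O)c2c1)c1cccc(C)c1` gives > 5000 nM, which is a limit and not a number. For the measured compounds named here, compound 2 `C#CCN(Cc1ccc2nc(C)nc(O)c2c1)c1cccc(CC)c1` gives 5000 nM, the only true number so far. Compound 3 `C#CCN(Cc1ccc2nc(C)nc(O)c2c1)c1cccc(CO)c1` differs from it by hydroxy in place of methyl on a saturated chain carbon bound to an aromatic carbon, that is, ethyl to hydroxymethyl. Going by the values given here, the sole measured step, a number no higher from compound 1 to compound 2 (the limit leaves the size open), has no readable size, so it gives no direction for this change. An expected step of no change at the digits printed from compound 2 to compound 3 (within the scatter) therefore stays within the scatter. The estimated value for compound 3 is 5000 nM, with an expected range of 2000 nM to 10000 nM.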

Compound 3, half-maximal inhibitory concentration: 48000 nM
Estimate against measurement, compound 3: 9.6-fold (0.98 log units) below; the measured number lies above the stated range.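

In this assay, the place on a saturated chain carbon bound to an aromatic carbon proves sensitive to hydroxy in place of methyl, with a 9.6-fold higher number from compound 2 to compound 3 (0.98 log units; beyond the scatter). For the compounds shown here, this is the first readable size at this place, and it runs towards weaker inhibition. The step that rests on the limit of compound 1 cannot be read: the limit of > 5000 nM in this assay, at which 1 of the 3 values shown sits.

The compounds shown leave open whether an aminomethyl, a carboxylic acid or a longer chain such as propyl at this place would stay level with compound 2 or fall away as compound 3 does. Going by these compounds, whether any group here gives stronger inhibition than compound 2 also stays open.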